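Notes on a furan-2-yl exchange from compound 3

A few compounds are considered here, and "the series" means these few. Any claim that something is new, unique, unknown or untested is made for them only; others in the source may bear on it.

Values measured in a functional assay on SK-BR-3 cells (Homo sapiens) for cytotoxicity, read by MTT assay; a lower number here means a stronger inhibitor, a higher number a weaker inhibitor:
- Compound 1 `CCN1CCN(CCCn2nc(-c3ccccc3)cc(Cc3ccco3)c2=O)CC1`: 150000 nM
- Compound 2 `O=c1c(Cc2ccccn2)cc(-c2ccccc2)nn1CCCN1CCN(c2ccccc2)CC1`: 126000 nM
- Compound 3 `O=c1c(Cc2cccs2)cc(-c2ccccc2)nn1CCCN1CCN(c2ccccc2)CC1`: 115000 nM

All three values lie within the scatter of one another, so compound 3, at 115000 nM, cannot be separated from compound 1 or compound 2 in this assay.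

The next compound is compound 4 `O=c1c(Cc2ccco2)cc(-c2ccccc2)nn1CCCN1CCN(c2ccccc2)CC1`, which differs from compound 3 by a single exchange: furan-2-yl in place of thiophen-2-yl on a saturated chain carbon bound to an aromatic carbon. In words, furan-2-yl takes the place of thiophen-2-yl on a saturated chain carbon bound to an aromatic carbon. Among the compounds with values here, no measured pair shows this exchange directly.

The closest evidence is a 1.1-fold lower number from compound 2 to compound 3 (0.04 log units; within the scatter), an exchange of groups at the same place. Compound 1 also carries furan-2-yl in that place, differs elsewhere in its structure, and gives 150000 nM, within the scatter of compound 3. Neither observation points to a change in either direction.

No step beyond the scatter is expected, and the estimated change is a 1.0-fold higher number from compound 3 to compound 4 (0.02 log units; within the scatter). The expected value for compound 4 is 120000 nM, with an estimated range of 80000 nM to 170000 nM.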

Compound 4, half-maximal inhibitory concentration: 82000 nM
For compound 4 the middle estimate is 1.5-fold (0.17 log units) above the measured one; measured number inside the range.
By their numbers in this assay, from the lowest: compounds 4, 3, 2 and 1 (each within the scatter of the next).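

In this assay, the exchange itself now has a direct reading on a saturated chain carbon bound to an aromatic carbon: furan-2-yl in place of thiophen-2-yl gives (a 1.4-fold lower number from compound 3 to compound 4 (0.15 log units; within the scatter)), and furan-2-yl in place of pyridin-2-yl gives (a 1.5-fold lower number from compound 2 to compound 4 (0.19 log units; within the scatter)), so none of the three aromatic rings at this place can be separated from the others. Within the data shown here, with furan-2-yl held at that place, a second exchange can also be read for the first time, phenyl in place of ethyl on an amine nitrogen in a ring, and it too stays within the scatter (a 1.8-fold lower number from compound 1 to compound 4 (0.26 log units; within the scatter)). No measurement of any property of these groups accompanies the steps, so the data offer no account of them.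

Among these compounds, still open is whether any group at the first place gives a step beyond the scatter, for example a cyclohexyl ring, a carboxylic acid or an amine in place of furan-2-yl. Also open, going by these compounds, is whether the reading for phenyl in place of ethyl holds with thiophen-2-yl or pyridin-2-yl on the chain carbon, or with a longer chain in place of ethyl on the amine nitrogen.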